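The source may hold more compounds than are shown below. What is called first, only, known or untested is meant among the compounds shown, and "the series" means these compounds.

In a functional assay on DU-145 cells (Homo sapiens) for inhibition, read by trypan blue exclusion, with a stated time of 96 h (a higher number here means a weaker inhibitor of growth, a lower number a stronger inhibitor of growth), compound 2 `Cc1ccc(CS(=O)(=O)/C(=C/c2c[nH]c3ccccc23)C(=O)c2ccc(Cl)cc2)cc1` gives 25000 nM. Among the measured compounds shown here, the only other measured compound, compound 1 `Cc1ccc(CS(=O)(=O)/C(=C/c2ccc(Br)cc2)C(=O)c2ccc(Cl)cc2)cc1`, gives 25000 nM, so compound 2 stands level with it. The open question is compound 3 `Cc1ccc(CS(=O)(=O)/C(=C/c2ccc(N(C)C)cc2)C(=O)c2ccc(Cl)cc2)cc1`, which keeps the shared core but carries 4-(dimethylamino)phenyl in place of 1H-indol-3-yl on a double-bonded chain carbon bound to a double-bonded chain carbon. The swap can be counted as 4-(dimethylamino)phenyl in place of 1H-indol-3-yl on a double-bonded chain carbon bound to a double-bonded chain carbon. For the measured compounds named here, only one measured step bears on this place: no change at the digits printed from compound 1 to compound 2 (within the scatter), where 1H-indol-3-yl replaced 4-bromophenyl. Going by the values given here, that single step is thin evidence, and no measured compound yet carries 4-(dimethylamino)phenyl, so a real shift in either direction remains possible. Still, the one replacement made here left the number unmoved, so no step beyond the scatter is expected in this assay. The estimated step of a 1.3-fold lower number from compound 2 to compound 3 (0.10 log units; within the scatter) therefore stays small. For compound 3, the expected value is 20000 nM, with an estimated range of 8000 nM to 40000 nM.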

Compound 3, concentration for 50% growth inhibition: 50000 nM
Estimate against measurement, compound 3: 2.5-fold (0.40 log units) below, outside the stated range (above it).
By their numbers in this assay, from the lowest: compounds 1, 2 and 3 (each within the scatter of the next).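

In this assay, the place on a double-bonded chain carbon bound to a double-bonded chain carbon has now taken a third group, and the reading shows a 2.0-fold higher number from compound 2 to compound 3 (0.30 log units; within the scatter). Comparing the two phenyl compounds gives a 2.0-fold higher number from compound 1 to compound 3 (0.30 log units; within the scatter), with dimethylamino in place of bromo on an aromatic carbon, so trading the hydrogen-bond donor of 1H-indol-3-yl for the hydrogen-bond acceptor of 4-(dimethylamino)phenyl, or bromo for dimethylamino, gives no step beyond the scatter in this read-out. Nothing independent of these growth readings is available to account for them.

As far as these compounds go, all three groups at this place are aromatic and of similar size, so it remains open whether something quite different there, such as a carboxylic acid or a longer saturated alkyl chain, would move the number beyond the scatter. From the compounds shown here alone, it is also open whether a smaller substituent on the phenyl ring, such as a nitrile or a methoxy group, would separate from these three compounds in either direction.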